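Nitro added to a second core: an expected gain

This account rests on a few compounds, and the source may have more. Where it says the series, first, only, none or still open, it means among the compounds named here.

Compound 1 `CCn1cc(-c2nc3ccccc3o2)c(=O)c2cc(F)c(N3CCNC(C)C3)c(F)c21` and compound 3 `CCn1cc(-c2nc3ccc([N+](=O)[O-])cc3o2)c(=O)c2cc(F)c(N3CCNC(C)C3)c(F)c21` share one core and differ in a single place. In a functional assay on KB cells (Homo sapiens) for cytotoxicity, read by MTT assay, with a stated time of 48 h (a lower number here means a stronger inhibitor, a higher number a weaker inhibitor), compound 1 gives 18900 nM, while compound 3 gives 600 nM. The change between them is nitro in place of hydrogen on an aromatic carbon. Among the measured compounds shown here, that step, a 32-fold lower number from compound 1 to compound 3 (1.50 log units; beyond the scatter), is the one counted step among the measured compounds.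

Compound 2 `CCn1cc(-c2nc3ccccc3s2)c(=O)c2cc(F)c(N3CCNCC3)nc21` has a different core; the difference between the two cores is not broken down here. In this assay compound 2 gives 2400 nM, which stands between the other two measured numbers.

Compound 4 `CCn1cc(-c2nc3ccc([N+](=O)[O-])cc3s2)c(=O)c2cc(F)c(N3CCNCC3)nc21` is the unmeasured partner of compound 2. The change from compound 2 to compound 4 is nitro in place of hydrogen on an aromatic carbon, and both its group and its place are described in the same words as the change from compound 1 to compound 3, so it is the same change made on the second core.

Whether the step repeats on this core rests on a single prior example, so the expectation carries wide uncertainty. Because a 32-fold lower number from compound 1 to compound 3 (1.50 log units; beyond the scatter) was large, compound 4 is expected to give a lower number than compound 2, with the estimated step of a 12-fold lower number from compound 2 to compound 4 (1.08 log units; beyond the scatter) taken somewhat smaller than the earlier one. Compound 4 is therefore estimated at 200 nM in this assay, expected to fall between 50 nM and 900 nM.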

Compound 4, half-maximal inhibitory concentration: 179000 nM
The estimate for compound 4 lay 900-fold (2.95 log units) below the measured number, outside the stated range (above it).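

In this assay, nitro in place of hydrogen on the core of compound 2 does not repeat what it did on the core of compound 1: the number moves the other way, with a 75-fold higher number from compound 2 to compound 4 (1.87 log units; beyond the scatter). Set side by side, the two results show that, in this series, the direction of this change on one core cannot be assumed to hold on another, even when the group and its place are described in the same words: the same change on two cores in this assay, a 32-fold lower number (1.50 log units; beyond the scatter) from compound 1 to compound 3 and a 75-fold higher number (1.87 log units; beyond the scatter) from compound 2 to compound 4, 2300-fold (3.37 log units) apart, beyond the scatter of two such steps. The result does not show which part of the difference between the two cores turns the step around, or why it does so, and each direction rests on a single pair of compounds.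

From the compounds shown here alone, it remains open how an amine or a carboxylic acid in place of the nitro group would behave on either core, and whether such a group would also give opposite steps on the two. Going by these compounds, it is equally open which direction the nitro step would take on a core that differs from the core of compound 1 in only one place, which is the kind of pair that could begin to separate the possible sources of the reversal.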